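A few compounds are considered here, and "the series" means these few. Any claim that something is new, unique, unknown or untested is made for them only; others in the source may bear on it.

Working notes on the series. In a functional assay on DU-145 cells (Homo sapiens) for cytotoxicity, read by MTT assay, with a stated time of 72 h (a lower number here means that less compound is needed, a higher number that more compound is needed for the effect), compound 1 `CCc1cccc2c(O)c(-c3occ(C)c3C(=O)O)ccc12` gives 8.7 ug/mL. Compound 2 `CCOC(=O)c1c(C)coc1-c1ccc2c(CC)cccc2c1OC` gives 2.2 ug/mL in this assay. Compound 3 `CCCOC(=O)c1c(C)coc1-c1ccc2c(CC)cccc2c1OC` reaches only the limit of the assay in this assay, reported as > 10 ug/mL, so for compound 3 no number is known, only a limit (the limit of > 10 ug/mL in this assay, at which 1 of the 3 values shown sits). For the measured compounds named here, the step of an at least 4.5-fold higher number from compound 2 to compound 3 (0.65 log units; beyond the scatter) is the only measured step in which one place changes. Going by the values given here, compound 1 differs from compound 2 in more than one place, so their two values are only set side by side and no step is drawn between them.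

Compound 4 `CCc1cccc2c(OC)c(-c3occ(C)c3C(=O)NC)ccc12` is the next compound. Relative to compound 3 the change is methylamino in place of propoxy on a carbonyl carbon. Among the compounds with values here, the measured step of an at least 4.5-fold higher number from compound 2 to compound 3 (0.65 log units; beyond the scatter) concerns the same carbonyl carbon but a different change, so it gives no direct measure for the step to compound 4; it shows only that the values respond to what sits on this carbonyl carbon. The estimated step is an at least 1.4-fold lower number from compound 3 to compound 4 (0.15 log units; that floor lies within the scatter), toward a number rather than a limit, with wide uncertainty on both sides. Compound 4 is expected to give about 7 ug/mL in this assay, between 2 ug/mL and 25 ug/mL.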

Compound 4, concentration for half-maximal effect: > 10 ug/mL
Compound 4: only a limit was reported; the forecaster's own chance of this, stated with the estimate: 35%; at least 1.4-fold (0.15 log units) between middle value and limit.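

In this assay, methylamino in place of ethoxy on the carbonyl carbon gives an at least 4.5-fold higher number from compound 2 to compound 4 (0.65 log units; beyond the scatter), so this position has now responded to a change of the atom attached to the carbonyl carbon as well as to a longer chain on the ester. Compound 4 is reported only as a limit of the assay, as is compound 3, and the step between these two compounds cannot be read: the limit of > 10 ug/mL in this assay, at which 2 of the 4 values shown sit. Among compound 2, compound 3 and compound 4, only the ethoxy of compound 2 gives a number rather than a limit, while compound 1 also gives a number but differs from compound 2 in more than one place, so this observation is confined to those three compounds.

From the compounds shown here alone, how far the true values of compound 3 and compound 4 lie past the limit remains open, so propoxy and methylamino cannot be ranked against each other. Also open, going by these compounds, is what methoxy or ethylamino on the same carbonyl carbon would give, which would help separate the effect of chain length from that of replacing the ester oxygen with nitrogen.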